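Benzofuranyl ketone piperazines: acetyl replacing 4-cyanophenyl

The source may hold more compounds than are shown below. What is called first, only, known or untested is meant among the compounds shown, and "the series" means these compounds.

Measured compounds:
compound 1, `C#CCN1CCN(CC(=O)N2CCN(c3ccc(C(=O)c4cc5ccc(N(CC)CC)cc5o4)cc3)CC2)CC1`; in a functional assay on A549 cells (Homo sapiens) for cytotoxicity, read by MTT assay, with a stated time of 48 h (on this read-out lower numbers stand for stronger inhibition and higher numbers for weaker inhibition), compound 1 gives > 40000 nM, a limit of the assay rather than a number.
compound 2, `CCN(CC)c1ccc2cc(C(=O)c3ccc(N4CCN(C(=O)CN5CCN(Cc6ccc(C#N)cc6)CC5)CC4)cc3)oc2c1`; in this assay compound 2 gives 17400 nM.

For the measured compounds named here, compound 2 holds the only numerical value shown; the other value is a limit. Going by the values given here, the one measured step runs an at least 2.2-fold lower number from compound 1 to compound 2 (0.36 log units; beyond the scatter), with the limit of > 40000 nM in this assay, at which 1 of the 2 values shown sits, setting the lower bound of that step.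

Compound 3, `CCN(CC)c1ccc2cc(C(=O)c3ccc(N4CCN(C(=O)CN5CCN(CC(C)=O)CC5)CC4)cc3)oc2c1`, has not yet been measured. It differs from compound 2 by acetyl in place of 4-cyanophenyl on a saturated chain carbon bound to an amine nitrogen in a ring. The change removes the aromatic ring that compound 2 carries on the ring amine nitrogen and leaves a short, smaller substituent there. Among the compounds with values here, the only step that bears on this position is the step from compound 1 to compound 2, which gained at least modestly on going from the small ethynyl group to the larger 4-cyanophenyl group. Compound 3 moves back toward a small substituent, so the number is expected to rise again, with the step of a 2.0-fold higher number from compound 2 to compound 3 (0.30 log units; within the scatter) estimated in the direction of weaker inhibition, and a fair chance that only a limit is returned. Compound 3 is therefore estimated at 35000 nM, within 14000 nM to 90000 nM.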

Compound 3, half-maximal inhibitory concentration: 8920 nM
Estimate against measurement, compound 3: 3.9-fold (0.59 log units) above; measured number below the stated range.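

In this assay, the aromatic ring of compound 2 proves dispensable at this position: a 2.0-fold lower number from compound 2 to compound 3 (0.29 log units; within the scatter), a step within the scatter, so acetyl (3 heavy atoms, no ring) and 4-cyanophenyl (8 heavy atoms, one six-membered aromatic ring) cannot be told apart on a saturated chain carbon bound to an amine nitrogen in a ring. The earlier step, an at least 2.2-fold lower number from compound 1 to compound 2 (0.36 log units; beyond the scatter), could be read as a gain tied to the larger group, but acetyl, also a small group, gives an at least 4.4-fold lower number from compound 1 to compound 3 (0.65 log units; beyond the scatter), so size alone does not account for the three compounds, and ethynyl is the group that stands apart from the other two. The value of compound 1 is a limit of the assay, and it sets the bound of both steps that start from that compound: the limit of > 40000 nM in this assay, at which 1 of the 3 values shown sits.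

From the compounds shown here alone, how far compound 1 really lies from the other two stays open, as its value gives only a bound. Also open, going by these compounds, is whether the read-out moves with a carboxylic acid, a primary amine or a longer chain in this place, or stays at the level of compound 2 and compound 3.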